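This account rests on a few compounds, and the source may have more. Where it says the series, first, only, none or still open, it means among the compounds named here.

The measured compounds:

Compound 1, `C#Cc1cccc(-n2ccc3cc(OC)cc(OC)c3c2=O)c1`: in a functional assay on A-431 cells (Homo sapiens) for antiproliferative activity, read by MTT assay, with a stated time of 72 h (a higher number here means a weaker inhibitor, a lower number a stronger inhibitor), compound 1 gives 7130 nM.
Compound 2, `C#Cc1cccc(-n2ccc3cc(OC)cc(O)c3c2=O)c1`: in this assay compound 2 gives 4440 nM.
Compound 3, `C=CC(=O)Nc1c(OC)cc(OC)c2c(=O)n(-c3cccc(C(=O)N4CCCCC4)c3)ccc12`: in this assay compound 3 gives 6230 nM.

Compound 1 and compound 2 share one core and differ in a single spot, (hydrogen in place of methyl on an oxygen on an aromatic ring). In this assay this change gave a 1.6-fold lower number from compound 1 to compound 2 (0.21 log units; within the scatter), so the two numbers cannot be told apart with confidence. Compound 3 is built on a different core; the difference between the two cores is not broken down here. Its number in this assay lies within the scatter of both compound 1 and compound 2, so all three read as about equally active.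

Compound 4, `C=CC(=O)Nc1c(OC)cc(O)c2c(=O)n(-c3cccc(C(=O)N4CCCCC4)c3)ccc12`, has not yet been measured. It differs from compound 3 by hydrogen in place of methyl on an oxygen on an aromatic ring, the same change, at the same kind of place, that separates compound 1 from compound 2. Because that earlier change produced only a 1.6-fold lower number from compound 1 to compound 2 (0.21 log units; within the scatter), the step from compound 3 to compound 4 in this assay is expected to be of similar small size, a 1.6-fold lower number from compound 3 to compound 4 (0.19 log units; within the scatter). On that basis compound 4 is estimated at 4000 nM in this assay, likely between 1500 nM and 11000 nM.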

Compound 4, half-maximal inhibitory concentration: 5300 nM
Compound 4: middle estimate off by 1.3-fold (0.12 log units), on the low side; the range from low to high includes it.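

In this assay, replacing methoxy with hydroxy on the core of compound 3 gave a 1.2-fold lower number from compound 3 to compound 4 (0.07 log units; within the scatter), so these two numbers cannot be told apart. Set beside the earlier case, the same change gave no readable shift on either core, and the two steps cannot be told from each other: the same change on two cores in this assay, a 1.6-fold lower number (0.21 log units; within the scatter) from compound 1 to compound 2 and a 1.2-fold lower number (0.07 log units; within the scatter) from compound 3 to compound 4, 1.4-fold (0.14 log units) apart, within the scatter of two such steps. This shows that the small size of the step held on both cores shown, but it does not show that the step would stay small on any other core, and with both steps inside the scatter it gives no true size or direction for the change.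

Only methoxy and hydroxy appear at this place on an oxygen on an aromatic ring, so the compounds shown leave open what a longer chain such as ethoxy, or a chain ending in an amine, would do there. They also leave open whether any such group would give a step beyond the scatter in this assay.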